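A Trifluoromethoxy Swap in a Series Without Measurable Cytotoxicity

The source may hold more compounds than are shown below. What is called first, only, known or untested is meant among the compounds shown, and "the series" means these compounds.

Compound 1, `CCOC(=O)CCCCCOc1cccc(CN(C(=O)c2ccc(-c3cnc(OC)nc3OC)cc2)C(C)C)c1`: in an ADME assay on Raji cells (Homo sapiens) for cytotoxicity, read by CellTiter-Glo and resazurin assay, with a stated time of 72 h (on this read-out lower numbers stand for an effect already at smaller amounts and higher numbers for an effect only at larger amounts of compound), compound 1 gives only the assay limit > 26000 nM.
Compound 2, `CCOC(=O)CCCCCOc1cccc(CN(C(=O)c2ccc(-c3cccc(OCc4ccccc4)c3)cc2)C(C)C)c1`: in this assay compound 2 gives only the assay limit > 26000 nM.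
Compound 3, `CCOC(=O)CCCCCOc1cccc(CN(C(=O)c2ccc(-c3cccc(OC)c3)cc2)C(C)C)c1`: in this assay compound 3 gives only the assay limit > 21000 nM.

Compound 3 thus stands at a limit, and the other two values shown are limits as well, marked by the limit of > 21000 nM in this assay, at which 1 of the 3 values shown sits, and (the limit of > 26000 nM in this assay, at which 2 of the 3 values shown sit). Compound 4, `CCOC(=O)CCCCCOc1cccc(CN(C(=O)c2ccc(-c3cccc(OC(F)(F)F)c3)cc2)C(C)C)c1`, differs from compound 3 by trifluoromethyl in place of methyl on an oxygen on an aromatic ring. The steps bearing on this position are a step that the two limits leave unreadable from compound 1 to compound 3 and a step that the two limits leave unreadable from compound 2 to compound 3, both left unreadable by the limits. No change in this assay beyond the scatter is therefore expected, and compound 4 is expected to stay at the limit, with the estimated step that the limit leaves unreadable from compound 3 to compound 4. Compound 4 is estimated at 30000 nM, ranging from 15000 nM to 60000 nM.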

Compound 4, half-maximal effective concentration: > 26000 nM
Compound 4: only a limit was reported; the forecaster's own chance of this, stated with the estimate: 80%; the middle value is on the limit's open side.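

In this assay compound 4 gives > 26000 nM, which is only a limit, so its steps from compound 1, compound 2 and compound 3 cannot be read. The compounds shown leave open where any of them would reach a half-maximal effect, and so whether trifluoromethyl in place of methyl changes anything.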